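A few compounds are considered here, and "the series" means these few. Any claim that something is new, unique, unknown or untested is made for them only; others in the source may bear on it.

Working notes on the series. Compound 1 `CC(=O)Nc1nc(C)nc2cn(-c3ccccc3)nc12` gives 25% in an assay on CHO cells for displacement of a labelled ligand from adenosine receptor A1 (Homo sapiens), read by scintillation counting, with a stated time of 120 min, tested at 1 uM (on this read-out higher numbers stand for more inhibition at the one concentration tested (going by the name of the read-out) and lower numbers for less inhibition), the higher of the two numbers in hand. Compound 2 `Cc1nc2cn(-c3ccccc3)nc2c(=O)[nH]1` gives 1% in this assay, a figure that sits beyond the scatter under compound 1. Compound 3 `Cc1nc(NC(=O)c2ccncc2)c2nn(-c3ccccc3)cc2n1` has not been measured. It differs from compound 1 in one place: pyridin-4-yl in place of methyl on a carbonyl carbon. Going by the values given here, no measured pair carries this change, so its effect is unknown. A modest rise from compound 1 to compound 3 is expected, of a size a number 10 percentage points higher from compound 1 to compound 3 (within the scatter) near the edge of the scatter. For compound 3 the expected value in this assay is 35%, with a range from 10% to 65%.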

Compound 3, a percentage reported as inhibition, at one concentration (the size of the read-out at that concentration, not a potency): 12%
The estimate for compound 3 lay 23 percentage points above the measured number, within the range that was stated.
By their numbers in this assay, from the lowest: compound 2; then compound 3; then compound 1.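

The carbonyl carbon of the amide is a position that responds to substitution: pyridin-4-yl in place of methyl gives a number 13 percentage points lower from compound 1 to compound 3 (beyond the scatter) in this assay. Adding this larger aromatic group therefore brings no gain in inhibition at the one concentration tested, and the smaller methyl holds the higher number of this pair. Nothing in hand accounts for the drop.

Open, from the compounds shown here alone, is whether the ring nitrogen matters, which phenyl on the same carbonyl carbon would test. Also open, going by these compounds, is how a longer chain such as propyl, or an amine such as dimethylamino, would read there.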